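The compounds below may be only part of what the source reports. "The series", "measured", "known", "first", "only" and "open" are said of these compounds alone.

Compound 1 `N#CC1=C(NCN2CCCC2)N(c2ccccc2)C(=O)N2CCCCC(N3CCCC3)C12` gives 26.6% in a functional assay on the whole organism (strain albino) for inhibition, with Rattus norvegicus as the target, read by paw edema, with stated times of 1 h and 2 h, at a dose of 20 mmol/kg by the intraperitoneal route; a higher number here means more inhibition at the dose given (going by the name of the read-out), a lower number less inhibition.
Compound 2 `N#CC1=C(/N=C/c2ccccc2)N(c2ccccc2)C(=O)N2CCCCC(N3CCCC3)C12` gives 75.9% in this assay.
Compound 3 `N#Cc1c2n(c(=O)n(-c3ccccc3)c1=N)CCCCC2N1CCCC1` gives 88.7% in this assay.

Among these three numbers compound 2 stands second highest: compound 3 lies above it and compound 1 lies well below it, and both gaps are beyond the usual scatter. The unmeasured compound 4 `COC(=O)C(=O)NC1=C(C#N)C2C(N3CCCC3)CCCCN2C(=O)N1c1ccccc1` differs from compound 2 in a single place: a group of 7 heavy atoms (3 carbon, 1 nitrogen, 3 oxygen; no ring) in place of a group of 8 heavy atoms (7 carbon, 1 nitrogen; one six-membered aromatic ring of carbon only), on a double-bonded ring carbon. Going by the values given here, one measured step bears on this change, since it alters the same double-bonded ring carbon of the shared core: a number 49.3 percentage points higher from compound 1 to compound 2 (beyond the scatter). That step shows that the group on this carbon can move the read-out by a large amount, and that the group with the aromatic ring gave the much higher number while the group with the non-aromatic ring gave the low one. Compound 4 removes the aromatic ring altogether and puts in its place a chain with no ring, so the expectation is a drop from compound 2 rather than a gain, though the new group is unlike either measured one and its size is uncertain. Compound 4 is therefore expected to give roughly 50%, within about 25% to 75%, which means an expected step of a number 25.9 percentage points lower from compound 2 to compound 4 (beyond the scatter).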

Compound 4, a percentage reported as inhibition, in the whole organism at one dose (the size of the read-out at that dose, not a potency): 85.6%
Compound 4: middle estimate off by 35.6 percentage points, on the low side; measured number outside the range, above it.
By their numbers in this assay, from the lowest: compound 1; then compounds 2, 4 and 3 (each within the scatter of the next, the first and the last beyond it).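

In this assay, the step of a number 9.7 percentage points higher from compound 2 to compound 4 (within the scatter) means that these two compounds cannot be told apart, so the six-membered aromatic ring of carbon only is not needed on this double-bonded ring carbon for a high number, and a group with no ring, ((methoxycarbonyl)carbonyl)amino, does as well. The large gap seen earlier between compound 1 and compound 2 therefore cannot be read simply as aromatic ring against no aromatic ring: a number 59 percentage points higher from compound 1 to compound 4 (beyond the scatter) when (methoxycarbonyl)carbonyl stands in place of (pyrrolidin-1-yl)methyl on the amine nitrogen, and among these three compounds only compound 1, with (pyrrolidin-1-yl)methyl, gives a low number. Nothing measured here explains why the read-out follows these groups at this position.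

From the compounds shown here alone, whether the number holds with a carboxylic acid in place of the methyl ester, or with a plain acetyl group on the amine nitrogen, remains open. Also open, going by these compounds, is what an ethyl ester, a longer chain or an unsubstituted amine on this carbon would give, so how much of the ((methoxycarbonyl)carbonyl)amino group matters cannot yet be said.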